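The source may report more compounds than this note shows. Statements on the series, on what has been measured and on what is new or still open speak of the compounds shown alone.

Values in a functional assay on MCF7 cells (Homo sapiens) for cytotoxicity, read by MTT assay, with a stated time of 72 h; on this read-out lower numbers stand for stronger inhibition and higher numbers for weaker inhibition:
- compound 1 `Cn1ccc2c(Oc3ccc(NC(=O)c4cc5cccnc5n(-c5ccc(Cl)cc5)c4=O)cc3F)ncnc21`: 75000 nM
- compound 2 `O=C(Nc1ccc(Oc2ncnc3[nH]ccc23)c(F)c1)c1cc2cccnc2n(-c2ccccc2)c1=O`: 45000 nM
- compound 3 `O=C(Nc1ccc(Oc2ncnc3[nH]ccc23)c(F)c1)c1cc2cccnc2n(-c2ccc(F)cc2)c1=O`: 9230 nM

Compound 3 has the lowest number of the three, and its gaps to both others lie beyond the scatter. Compound 4 `O=C(Nc1ccc(Oc2ncnc3[nH]ccc23)c(F)c1)c1cc2cccnc2n(-c2ccc(Cl)cc2)c1=O` keeps the core of compound 3 and changes one group, 4-fluorophenyl to 4-chlorophenyl: chloro in place of fluoro on an aromatic carbon.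

Among the measured compounds shown here, one measured step bears on this place: a 4.9-fold lower number from compound 2 to compound 3 (0.69 log units; beyond the scatter), a modest change with fluoro in place of hydrogen on an aromatic carbon. It shows that the number can move with this substituent, but it does not measure chloro against fluoro. For the measured compounds named here, compound 1 also carries the 4-chlorophenyl group and gives 75000 nM, yet no measured pair isolates that group. A small rise in the number is therefore expected, possibly within the scatter, starting from compound 3 at 9230 nM. The expected change is a 1.5-fold higher number from compound 3 to compound 4 (0.18 log units; within the scatter). Compound 4 is estimated at 14000 nM, with an expected range from 4500 nM to 40000 nM.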

Compound 4, half-maximal inhibitory concentration: 45000 nM
For compound 4 the middle estimate is 3.2-fold (0.51 log units) below the measured one; measured number above the stated range.
By their numbers in this assay, from the lowest: compound 3; then compounds 2, 4 and 1 (each within the scatter of the next).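

In this assay, this place on the aromatic ring proves sensitive to which halogen it carries, not merely to whether one is present: chloro in place of fluoro gives a 4.9-fold higher number from compound 3 to compound 4 (0.69 log units; beyond the scatter). Chloro in place of hydrogen gives no change at the digits printed from compound 2 to compound 4 (within the scatter), so among hydrogen, fluoro and chloro, only fluoro stands apart here, its number lying beyond the scatter of the other two. With the 4-chlorophenyl group kept, hydrogen in place of methyl on the aromatic nitrogen gives a 1.7-fold lower number from compound 1 to compound 4 (0.22 log units; within the scatter), a step too small to read as a change, and nothing available accounts for these results.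

The compounds shown leave open whether a methoxy, nitrile or amine at this place would give a number as low as fluoro's or a lower one. They also leave open how the methyl on the aromatic nitrogen would act alongside the 4-fluorophenyl group.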